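Thiazolidinone benzamides: ring-nitrogen aryl change from compound 2

The source may hold more compounds than are shown below. What is called first, only, known or untested is meant among the compounds shown, and "the series" means these compounds.

Measured so far:
- compound 1, `COc1ccc(F)cc1N1C(=O)CSC1c1cccc(C(=O)NCCCCn2cccn2)c1`: 97.3 nM
- compound 2, `O=C(NCCCCc1ccccc1)c1cccc(C2SCC(=O)N2c2ccccc2)c1`: 15.9 nM

Both were run in a functional assay on HOS-TE85 cells (Homo sapiens) for inhibition, read by CCK-8 assay, with a stated time of 72 h; on this read-out lower numbers stand for stronger inhibition and higher numbers for weaker inhibition. Compound 2 gives the lowest of the two numbers in this assay; its nearest neighbour is compound 1, whose number is higher by an amount beyond the scatter. Going by the values given here, compound 1 and compound 2 differ in more than one place, so no single-step comparison between them is available, and the two values show only that compound 2 sits well below compound 1.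

The next compound, compound 3, `COc1cccc(OC)c1N1C(=O)CSC1c1cccc(C(=O)NCCCCc2ccccc2)c1`, differs from compound 2 in one place: 2,6-dimethoxyphenyl in place of phenyl on an amide-type nitrogen in a ring

Among the compounds with values here, no measured pair isolates this change. Compound 1, which also carries a substituted aryl group on the ring nitrogen, gives 97.3 nM in this assay, but its amide chain differs as well, so it cannot carry the argument. The expectation for compound 3 is therefore a modest weakening, with a 2.2-fold higher number from compound 2 to compound 3 (0.34 log units; beyond the scatter) as the estimated step, and a wide range. Compound 3 is expected to give about 35 nM in this assay, between 10 nM and 120 nM.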

Compound 3, half-maximal inhibitory concentration: > 1000 nM
Compound 3 gave a limit, no number; the forecaster's own chance of this, stated with the estimate: 5%; middle value at least 28-fold (1.45 log units) away from the limit.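

Going by these compounds alone, replacing phenyl with 2,6-dimethoxyphenyl on the amide-type nitrogen in the ring is the only single-place change read so far, and in this assay it gives an at least 62-fold higher number from compound 2 to compound 3 (1.79 log units; beyond the scatter). The reading for compound 3 is a limit of the assay and not a number, so this step fixes only a minimum size, and its full size stays unread: the limit of > 1000 nM in this assay, at which 1 of the 3 values shown sits. With the phenylbutyl amide chain and the shared core unchanged, the loss of measurable inhibition within this range belongs to this one aryl exchange, which shows that this position does not accept every aryl group and that the change can be large.

The compounds shown do not separate the effect of the 2,6-dimethoxyphenyl group into its parts, and compound 1 cannot help, since its amide chain differs as well as its aryl group. Going by these compounds, whether a phenyl ring carrying a single methyl group or a single chlorine atom keeps the inhibition of compound 2 remains open, as does the effect of the same aryl change on a different amide chain.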